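A nitrophenyl amide ester series: swapping the ortho substituent

This account rests on a few compounds, and the source may have more. Where it says the series, first, only, none or still open, it means among the compounds named here.

Three esters of the same core have been measured in a functional assay on MCF7 cells (Homo sapiens) for inhibition, read by MTT assay, with a stated time of 72 h; on this read-out lower numbers stand for stronger inhibition and higher numbers for weaker inhibition. Compound 1 `COc1ccc(C(=O)OC2(C(=O)Nc3ccc([N+](=O)[O-])cc3)CCCCC2)cc1` gives 41.2 nM. Among the measured compounds shown here, compound 2 `O=C(OC1(C(=O)Nc2ccc([N+](=O)[O-])cc2)CCCCC1)c1ccc(Br)cc1` gives 237 nM, and the step of a 5.8-fold higher number from compound 1 to compound 2 (0.76 log units; beyond the scatter) is the only single-point change among the measured compounds. Compound 3 `CCOC(=O)c1ccccc1C(=O)OC1(C(=O)Nc2ccc([N+](=O)[O-])cc2)CCCCC1` gives 444 nM; this number sits within the scatter of compound 2 and lies beyond the scatter above compound 1, which has the lowest number of the three.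

Compound 4 `CC(=O)Oc1ccccc1C(=O)OC1(C(=O)Nc2ccc([N+](=O)[O-])cc2)CCCCC1` differs from compound 3 by acetoxy in place of ethoxycarbonyl on an aromatic carbon. For the measured compounds named here, no measured step touches this position: the one step known, from methoxy to bromo, changes a different ring and a different kind of group, so it offers no guide to the size or direction of the present change. With nothing to lean on, the expectation for compound 4 is a number close to that of compound 3, with a 1.1-fold lower number from compound 3 to compound 4 (0.05 log units; within the scatter) staying within the scatter; compound 4 is therefore estimated at 400 nM, between 150 nM and 1200 nM.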

Compound 4, half-maximal inhibitory concentration: 16.9 nM
Beside the measured number, compound 4's estimate is 24-fold (1.37 log units) above it, and the stated range ends above it.
By their numbers in this assay, from the lowest: compound 4; then compound 1; then compounds 2 and 3 (each within the scatter of the next).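

In this assay the group on this aromatic carbon, ortho to a large group, proves decisive: acetoxy in place of ethoxycarbonyl gives a 26-fold lower number from compound 3 to compound 4 (1.42 log units; beyond the scatter) even though the two groups have the same counts of hydrogen-bond donors and acceptors. The 2-acetoxyphenyl group also gives a 14-fold lower number from compound 2 to compound 4 (1.15 log units; beyond the scatter) against 4-bromophenyl and the smaller 2.4-fold lower number from compound 1 to compound 4 (0.39 log units; beyond the scatter) against 4-methoxyphenyl, so compound 4 has the lowest number of the four. Nothing measured here accounts for the size of this change.

As far as these compounds go, it remains open whether a hydroxyl, a carboxylic acid or a longer acyl chain on this aromatic carbon would keep such a low number, or whether acetoxy would do so elsewhere on the ring. Also open, from the compounds shown here alone, is whether the step would carry over to a core with an amine in place of the nitro group.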